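Removing a methoxy group from the core of compound 1

A few compounds are considered here, and "the series" means these few. Any claim that something is new, unique, unknown or untested is made for them only; others in the source may bear on it.

Compound 1 `COc1ccc2c(/C=C/C(=O)c3cc(OC)c(OC)c(SC)c3)cn(C)c2c1` gives 166 nM in a functional assay on MCF7 cells (Homo sapiens) for antiproliferative activity, read by MTT assay, with a stated time of 48 h; on this read-out higher numbers stand for weaker inhibition and lower numbers for stronger inhibition. Two related compounds were measured alongside it: compound 2 `COc1ccc2c(/C=C(\C)C(=O)c3cc(OC)c(OC)c([Se]C)c3)c[nH]c2c1` gives 35 nM, and compound 3 `COc1cc(C(=O)/C(C)=C/c2c[nH]c3ccccc23)cc([Se]C)c1OC` gives 59 nM. The difference between the core of compound 1 and that of compound 2 is not broken down here. From compound 2 to compound 3 one change was made, (hydrogen in place of methoxy on an aromatic carbon), and it gave a 1.7-fold higher number from compound 2 to compound 3 (0.23 log units; within the scatter). The same change applied to compound 1 yields compound 4 `COc1cc(C(=O)/C=C/c2cn(C)c3ccccc23)cc(SC)c1OC`, which has not yet been measured; the change is hydrogen in place of methoxy on an aromatic carbon. Because a 1.7-fold higher number from compound 2 to compound 3 (0.23 log units; within the scatter) was small, a step of similar size is expected from compound 1 to compound 4, namely a 1.6-fold higher number from compound 1 to compound 4 (0.19 log units; within the scatter). Compound 4 is therefore estimated at 260 nM, with a likely range from 110 nM to 600 nM.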

Compound 4, half-maximal inhibitory concentration: 102 nM
Compound 4: the middle estimate sits 2.5-fold (0.41 log units) above what was measured; the measured number lies below the stated range.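

Removing the methoxy group from the core of compound 1 gave a 1.6-fold lower number from compound 1 to compound 4 (0.21 log units; within the scatter) in this assay. Each step is small on its own, yet the two do not agree when set side by side: the same change on two cores in this assay, a 1.7-fold higher number (0.23 log units; within the scatter) from compound 2 to compound 3 and a 1.6-fold lower number (0.21 log units; within the scatter) from compound 1 to compound 4, 2.7-fold (0.44 log units) apart, beyond the scatter of two such steps. The step seen on one core is therefore not a safe guide to the step on the other, but these two pairs do not show which of the differences between the cores is responsible, or how the change would behave on any further core.

Also open, on these data alone, is what a group other than methoxy, such as an amine or a fluorine atom, would do on this aromatic carbon. As far as these compounds go, whether either core would respond in the same way to such a group also remains unknown.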